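A few compounds are considered here, and "the series" means these few. Any claim that something is new, unique, unknown or untested is made for them only; others in the source may bear on it.

Measured compounds:
compound 1 `ClCc1ccccc1Cn1cnc2c(Cl)nc(Cl)nc21`: 1990 nM
compound 2 `ClCc1ccccc1Cn1cnc2c(Cl)ncnc21`: 7240 nM
compound 3 `ClCc1ccc(Cn2cnc3c(Cl)nc(Cl)nc32)cc1`: 46800 nM

In a functional assay on NCI-H522 cells (Homo sapiens) for cytotoxicity, read by sulforhodamine B assay, with a stated time of 48 h (on this read-out higher numbers stand for weaker inhibition of growth and lower numbers for stronger inhibition of growth), compound 2 stands second highest of the three numbers; the nearest is compound 1 with 1990 nM, the furthest compound 3 with 46800 nM. Compound 4 `Nc1nc(Cl)c2ncn(Cc3ccccc3CCl)c2n1` differs from compound 2 by amino in place of hydrogen on an aromatic carbon, on an aromatic carbon of a six-membered aromatic ring with 2 nitrogen, between two ring nitrogen atoms. For the measured compounds named here, the one single-point step on record, a 3.6-fold higher number from compound 1 to compound 2 (0.56 log units; beyond the scatter), exchanges chloro for hydrogen at that same carbon; it shows the position matters modestly, but no amino step is available. The step from compound 2 to compound 4 is therefore expected to be small, a 1.4-fold lower number from compound 2 to compound 4 (0.16 log units; within the scatter), with direction uncertain. Compound 4 is estimated at 5000 nM, range 1500 nM to 16000 nM.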

Compound 4, concentration for total growth inhibition: 9330 nM
For compound 4 the middle estimate is 1.9-fold (0.27 log units) below the measured one; measured number inside the range.
By their numbers in this assay, from the lowest: compound 1; then compounds 2 and 4 (each within the scatter of the next); then compound 3.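

At the carbon between two ring nitrogen atoms, amino and hydrogen do not separate: a 1.3-fold higher number from compound 2 to compound 4 (0.11 log units; within the scatter). Chloro does separate from amino, with a 4.7-fold higher number from compound 1 to compound 4 (0.67 log units; beyond the scatter), so among compounds 1, 2 and 4 the lower number occurs with chloro alone. The amino group, with its hydrogen-bond donor, therefore does not reproduce the chloro result at this carbon. No supporting data account for this difference. Still open, from the compounds shown here alone, is whether fluoro, methoxy or dimethylamino at this carbon would match chloro, and whether the same order would hold with the chloromethyl placement of compound 3.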